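The compounds below may be only part of what the source reports. "The series", "measured", "known", "first", "only" and "open" are said of these compounds alone.

Measured so far in a functional assay on BMDM cells (Mus musculus, strain C57BL/6) for inhibition, with a stated time of 2 days; on this read-out lower numbers stand for stronger inhibition and higher numbers for weaker inhibition:
compound 1 `Nc1cccc(-c2cn(CC(=O)Nc3nccs3)nn2)c1` gives 1270 nM
compound 2 `Cc1csc(NC(=O)Cn2cc(-c3cccc(N)c3)nn2)n1` gives 250 nM

Compound 1 stands at the higher of the two numbers recorded. Among the compounds with values here, its only neighbour is compound 2, reached by a 5.1-fold lower number from compound 1 to compound 2 (0.71 log units; beyond the scatter), the change being methyl in place of hydrogen on an aromatic carbon of the thiazole end of the shared core.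

Compound 3 `O=C(Cn1cc(-c2ccncc2)nn1)Nc1nccs1` has not yet been measured. It differs from compound 1 as follows: pyridin-4-yl in place of 3-aminophenyl on an aromatic carbon. Within the data shown here, the single measured step concerns the opposite end of the shared core and says nothing about the group carried on the five-membered aromatic ring with 3 nitrogen; no measured pair addresses pyridin-4-yl in place of 3-aminophenyl, so the size and direction of this step have no precedent. The expectation therefore rests on compound 1 alone, and the step of a 1.6-fold higher number from compound 1 to compound 3 (0.20 log units; within the scatter) is expected to be small relative to the wide uncertainty, with weakening somewhat more likely than strengthening. For compound 3 the estimate in this assay is 2000 nM, within the range 500 nM to 8000 nM.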

Compound 3, half-maximal inhibitory concentration: 2 nM
Compound 3: the middle estimate sits 1000-fold (3.00 log units) above what was measured, and the stated range ends above it.
By their numbers in this assay, from the lowest: compound 3; then compound 2; then compound 1.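

In this assay the group on the aromatic carbon of the five-membered aromatic ring with 3 nitrogen proves the more sensitive of the two places examined: the change there gives a 640-fold lower number from compound 1 to compound 3 (2.80 log units; beyond the scatter), whereas methyl in place of hydrogen at the thiazole end gives a 5.1-fold lower number from compound 1 to compound 2 (0.71 log units; beyond the scatter) in the same assay. The series can therefore move far at this position with one six-membered aromatic ring replacing another, from 3-aminophenyl with 1 hydrogen-bond donor and 1 hydrogen-bond acceptor to pyridin-4-yl with 0 hydrogen-bond donors and 1 hydrogen-bond acceptor. No supporting measurement accounts for this step, and which of these differences matters cannot be told from it.

Still open is whether the methyl step and the pyridin-4-yl step add up on a single core, as each is shown only as a separate change from compound 1. Also open, going by these compounds, is what a plain phenyl or a pyridin-3-yl would give at this carbon, which would separate the loss of the amine from the entry of a ring nitrogen and test how much its location counts.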